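Chain Extension in Three Compounds at the Same Limit

A few compounds are considered here, and "the series" means these few. Any claim that something is new, unique, unknown or untested is made for them only; others in the source may bear on it.

Compound 1 `C=COC(=O)[C@H](CC(C)C)NC(=O)[C@H](CC(C)C)NC(=O)[C@H](CC(C)C)NC(=O)CCNC(=O)OCc1ccccc1`: in an ADME assay on a cell-free system (plasma, Homo sapiens) for metabolic stability, with Plasma (Rattus norvegicus) as the target (a lower number here means that the compound disappears faster, a higher number that the compound lasts longer), compound 1 gives > 6 h, which is a limit of the assay and not a number.
Compound 2 `C=COC(=O)[C@H](CC(C)C)NC(=O)[C@H](CC(C)C)NC(=O)[C@H](CC(C)C)NC(=O)CCCNC(=O)OCc1ccccc1`: in this assay compound 2 gives > 6 h, again a limit of the assay.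
Compound 3 `C=COC(=O)[C@H](CC(C)C)NC(=O)[C@H](CO)NC(=O)[C@@H](NC(=O)CCCCNC(=O)OCc1ccccc1)C(C)C`: in this assay compound 3 gives > 6 h, also a limit of the assay.

Compound 2 arises from compound 1 by ((benzyloxycarbonyl)amino)methyl in place of (benzyloxycarbonyl)amino on a saturated chain carbon, two bonds along the chain from a carbonyl carbon. The resulting step is a step that the two limits leave unreadable from compound 1 to compound 2, since both ends sit at the same limit; all three measured values share this ceiling, (the limit of > 6 h in this assay, at which 3 of the 3 values shown sit). How the core of compound 3 differs from that of compound 1 is not broken down here.

Compound 4 `C=COC(=O)[C@H](CC(C)C)NC(=O)[C@H](CO)NC(=O)[C@@H](NC(=O)CCCCCNC(=O)OCc1ccccc1)C(C)C` arises from compound 3 by ((benzyloxycarbonyl)amino)methyl in place of (benzyloxycarbonyl)amino on a saturated chain carbon, four bonds along the chain from a carbonyl carbon. This is the same kind of change as that from compound 1 to compound 2, though not the same: there the new group sits two bonds along the chain from a carbonyl carbon, here four bonds along the chain from a carbonyl carbon.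

The step that the limit leaves unreadable from compound 3 to compound 4 is expected to be small and, like its counterpart, probably unreadable, because compound 3 already sits at the limit described by the limit of > 6 h in this assay, at which 3 of the 3 values shown sit. Compound 4 is therefore estimated to give 8 h in this assay, expected to fall between 4 h and 16 h.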

Compound 4, half-life: > 6 h
Compound 4 was reported as a limit (the forecaster's own chance of this, stated with the estimate: 85%); the middle value does not contradict the limit.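

Among these compounds, compound 3 and compound 4 are both reported only as a limit, so no step between them can be read: the limit of > 6 h in this assay, at which 4 of the 4 values shown sit.

The compounds shown leave open how long any of them actually lasts in this assay, and whether the longer chain changes that half-life at all.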